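Replacing the Methoxy Group of Compound 3

The source may report more compounds than this note shows. Statements on the series, on what has been measured and on what is new or still open speak of the compounds shown alone.

Among the measured compounds shown here, in an ADME assay on L1210 cells (Mus musculus) for cytotoxicity, with a stated time of 48 h (a lower number here means a stronger inhibitor, a higher number a weaker inhibitor), compound 3 `COC1=CC(=O)C(O)=C(C/C=C(\C)CC[C@@]2(C)CCC=C(C)[C@H]2C)C1=O` gives 2 ug/mL as the only true number so far. Compound 1 `CC1=CCC[C@](C)(CC/C(C)=C/CC2=C(O)C(=O)C=C(N[C@@H](C(=O)O)[C@@H](C)O)C2=O)[C@@H]1C` gives > 10 ug/mL as a limit of the assay. Compound 2 `CC1=CCC[C@](C)(CC/C(C)=C/CC2=C(O)C(=O)C=C(N[C@H](CO)C(=O)O)C2=O)[C@@H]1C` gives > 10 ug/mL as a limit too. Compound 4 `CC1=CCC[C@](C)(CC/C(C)=C/CC2=C(O)C(=O)C=C(N[C@H](C(=O)O)[C@H](C)O)C2=O)[C@@H]1C` is the next to be measured. Its change from compound 3 is (1-carboxy-2-hydroxypropyl)amino in place of methoxy on a double-bonded ring carbon so that (1-carboxy-2-hydroxypropyl)amino stands in place of methoxy on a double-bonded ring carbon. The same swap run the other way gave an at least 5.0-fold lower number from compound 1 to compound 3 (0.69 log units; beyond the scatter) and a closely similar swap gave an at least 5.0-fold lower number from compound 2 to compound 3 (0.69 log units; beyond the scatter) and both lie beyond the scatter. In this assay the expected step is a 10-fold higher number from compound 3 to compound 4 (1.00 log units; beyond the scatter) toward weaker inhibition. For compound 4 the estimated value is 20 ug/mL within a range from 8 ug/mL to 60 ug/mL and it may well appear only as a limit.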

Compound 4, half-maximal inhibitory concentration: > 10 ug/mL
Compound 4 was reported as a limit; the forecaster's own chance of this, stated with the estimate: 85%; the middle value is on the limit's open side.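

In this assay, putting (1-carboxy-2-hydroxypropyl)amino in place of methoxy on this double-bonded ring carbon gives an at least 5.0-fold higher number from compound 3 to compound 4 (0.69 log units; beyond the scatter). The weaker result therefore also holds for a second drawn form of this side chain, since compound 4 changes only the configuration of compound 1: the fact that compounds 1 and 4 differ only in the configuration as drawn. The steps among compounds 1, 2 and 4 cannot be read, because all three stop at the same limit: the limit of > 10 ug/mL in this assay, at which 3 of the 4 values shown sit.

Any effect of configuration or of the extra methyl therefore stays hidden. Also open, from the compounds shown here alone, is how a small group on this carbon, such as ethoxy or a plain amine, would compare with methoxy.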